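The source may report more compounds than this note shows. Statements on the series, on what has been measured and on what is new or still open speak of the compounds shown alone.

Three compounds have been measured so far in an ADME assay on HeLa cells (Homo sapiens) for cytotoxicity, read by MTT assay (a lower number here means a stronger inhibitor, a higher number a weaker inhibitor), as follows:
- compound 1 `CCN(CC)C(=O)CCC(=O)Oc1ccc(C[C@H]2C(=O)OC[C@@H]2Cc2ccc(OC)c(OC)c2)cc1OC` gives 213000 nM
- compound 2 `COc1ccc(C[C@H]2COC(=O)[C@@H]2Cc2ccc(OCc3cn(Cc4ccc(F)cc4)nn3)c(OC)c2)cc1OC` gives 198000 nM
- compound 3 `COc1ccc(C[C@H]2COC(=O)[C@@H]2Cc2ccc(OCc3cn(-c4ccc(Cl)cc4)nn3)c(OC)c2)cc1OC` gives 279000 nM

These three values lie within the scatter of one another, so compound 1 stands level with compound 2 and compound 3. Compound 4 `COC(=O)[C@H](CCSC)NC(=O)CCC(=O)Oc1ccc(C[C@H]2C(=O)OC[C@@H]2Cc2ccc(OC)c(OC)c2)cc1OC` has not yet been measured. It differs from compound 1 (1-(methoxycarbonyl)-3-(methylsulfanyl)propyl)amino in place of diethylamino on a carbonyl carbon with (1-(methoxycarbonyl)-3-(methylsulfanyl)propyl)amino in place of diethylamino on a carbonyl carbon.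

For the measured compounds named here, only one measured step is available as a guide, and it bears on this change only indirectly. That step is a 1.4-fold higher number from compound 2 to compound 3 (0.15 log units; within the scatter) with 4-chlorophenyl in place of 4-fluorobenzyl on an aromatic nitrogen. Going by the values given here, it sits at another place and stays within the scatter, and no measured step touches the carbonyl carbon in question. The data therefore favour neither direction, and no step beyond the scatter is expected in this assay for this change. The expected value for compound 4 is 200000 nM with an estimated range of 100000 nM to 400000 nM for repeated measurements. This estimate means a 1.1-fold lower number from compound 1 to compound 4 (0.03 log units; within the scatter) as the expected step.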

Compound 4, half-maximal inhibitory concentration: 199000 nM
Compound 4: the middle estimate sits 1.0-fold (0.00 log units) above what was measured, within the range that was stated.
By their numbers in this assay, from the lowest: compounds 2, 4, 1 and 3 (each within the scatter of the next).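

In this assay, for the compounds shown here, (1-(methoxycarbonyl)-3-(methylsulfanyl)propyl)amino in place of diethylamino on a carbonyl carbon gives a 1.1-fold lower number from compound 1 to compound 4 (0.03 log units; within the scatter), the first step that can be read at this position, since the earlier step lay at another place. The entering group has 10 heavy atoms against 5 in diethylamino, and it brings 1 hydrogen-bond donor, 3 hydrogen-bond acceptors, a sulfur atom and 1 defined stereocentre, yet compound 4 stands level with compound 1 in this assay, so in this one pair this substantial change on the carbonyl carbon leaves the read-out within the scatter. No measurement shown explains why these two groups read alike.

The compounds shown leave open whether a free carboxylic acid in place of the methoxycarbonyl part of the entering group, or the opposite configuration at its stereocentre, would also stay level with compound 4. They also leave open whether a ring amine such as piperidine or morpholine on the same carbonyl carbon would stay level with compound 1.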